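The source may report more compounds than this note shows. Statements on the series, on what has been measured and on what is new or still open speak of the compounds shown alone.

In a toxicity assay on HT-29 cells (Homo sapiens) for cytotoxicity (on this read-out higher numbers stand for lower toxicity in this test and lower numbers for higher toxicity in this test), compound 1 `CCCCn1nc(C(=O)N[C@H]2COc3ccccc3N(C)C2=S)nc1Cc1ccccc1` gives > 100000 nM as a limit of the assay. Compound 2 `CC(C)n1nc(C(=O)N[C@H]2COc3ccccc3N(C)C2=S)nc1Cc1ccccc1` gives > 100000 nM as a limit too. Compound 3 `CC(C)Cn1nc(C(=O)N[C@H]2COc3ccccc3N(C)C2=S)nc1Cc1ccccc1` gives > 100000 nM as a limit as well. For the measured compounds named here, the series so far stands at the limit of > 100000 nM in this assay, at which 3 of the 3 values shown sit, with no number for any compound. The change to compound 4 `COCCn1nc(C(=O)N[C@H]2COc3ccccc3N(C)C2=S)nc1Cc1ccccc1` is methoxymethyl in place of isopropyl on a saturated chain carbon bound to an aromatic nitrogen. The measured steps closest to it are (a step that the two limits leave unreadable from compound 2 to compound 3) and (a step that the two limits leave unreadable from compound 1 to compound 3) and (a step that the two limits leave unreadable from compound 1 to compound 2), none with a readable size. No step beyond the scatter is expected in this assay and no direction can be given. The expected outcome is (a number no higher from compound 3 to compound 4 (the limit leaves the size open)) for this change. Compound 4 is estimated at 100000 nM with an expected range from 50000 nM to 200000 nM and a report as a limit is likely.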

Compound 4, half-maximal cytotoxic concentration: > 100000 nM
Compound 4: a limit, no number (the forecaster's own chance of this, stated with the estimate: 85%); the middle value sits exactly at the limit.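

In this assay compound 4 gives > 100000 nM as a limit, so its steps from compound 1, compound 2 and compound 3 cannot be read. The compounds shown leave open whether any of these chains on the aromatic nitrogen changes the read-out, as all of them sit at one limit: the limit of > 100000 nM in this assay, at which 4 of the 4 values shown sit.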